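The compounds below may be only part of what the source reports. "The series", "measured", "known", "first", "only" and "open" are said of these compounds alone.

In an ADME assay on HEK293 cells (Homo sapiens) for cytotoxicity, read by fluorescence and resazurin assay, with a stated time of 24 h (on this read-out higher numbers stand for lower toxicity in this test and lower numbers for higher toxicity in this test), compound 2 (`Nc1ccc(-c2nnc(SC3=CS(=O)(=O)c4ccccc43)o2)cc1`) gives 4000 nM and stands level with compound 1 (`O=S1(=O)C=C(Sc2nnc(-c3cccnc3)o2)c2ccccc21`) at 4000 nM and compound 3 (`O=S1(=O)C=C(Sc2nnc(-c3ccccc3Cl)o2)c2ccccc21`) at 4000 nM on the numbers shown. Compound 4 (`CC(=O)Nc1ccc(-c2nnc(SC3=CS(=O)(=O)c4ccccc43)o2)cc1`) has not yet been measured. Compared with compound 2, it carries acetyl in place of hydrogen on a nitrogen on an aromatic ring. Going by the values given here, no measured step alters that nitrogen directly. The nearest evidence comes from exchanges of the aromatic group, which show no change at the digits printed from compound 1 to compound 2 (within the scatter) and no change at the digits printed from compound 1 to compound 3 (within the scatter) and no change at the digits printed from compound 2 to compound 3 (within the scatter) as well. On that limited basis, no step beyond the scatter is expected in this assay and the expected step is no change at the digits printed from compound 2 to compound 4 (within the scatter) in this case. Compound 4 is estimated at 4000 nM with an expected range of 1500 nM to 10000 nM for this measurement.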

Compound 4, half-maximal cytotoxic concentration: 4000 nM
Estimate against measurement, compound 4: no gap at the digits printed; the measured number falls inside the stated range.
By their numbers in this assay, from the lowest: compounds 1, 2, 3 and 4 (each within the scatter of the next).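

In this assay, the change from amino to acetamido gives no change at the digits printed from compound 2 to compound 4 (within the scatter). This is the first step shown that alters the nitrogen itself, where the earlier steps exchanged the whole aromatic group, so the read-out now stays level across a change at that nitrogen as well. Nothing shown gives a reason for this result. On these data alone, it remains open whether a longer chain such as butanoyl, or a carboxylic acid on that nitrogen, would also leave the value level. The compounds shown also leave open whether any change to the shared core would move it.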